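A few compounds are considered here, and "the series" means these few. Any claim that something is new, unique, unknown or untested is made for them only; others in the source may bear on it.

Working notes on the series.

Compound 1 `Cc1ccc(C)c(N2CCN(C(=O)c3oc(C)nc3-c3ccccc3)CC2)c1` is the reference point. Among the measured compounds shown here, in a functional assay on HL-60 cells (Homo sapiens) for inhibition, read by MTT assay, with a stated time of 72 h (a higher number here means a weaker inhibitor, a lower number a stronger inhibitor), compound 1 gives 31.3 nM, the only single number so far in the set. The two other entries are not single numbers. Compound 2 `Cc1ccc(C)c(N2CCN(C(=O)c3oc(C)nc3-c3ccccc3Cl)CC2)c1` reaches only (the limit of > 1000 nM in this assay, at which 1 of the 3 values shown sits), recorded as > 1000 nM, and this is a limit of the assay rather than a number. Compound 3 `Cc1ccc(C)c(N2CCN(C(=O)c3oc(C)nc3-c3ccc(Cl)cc3)CC2)c1` is recorded in this assay as "not active" (no number reported) without a number. For the measured compounds named here, the one measured step, an at least 31-fold higher number from compound 1 to compound 2 (1.50 log units; beyond the scatter), concerns chloro in place of hydrogen on an aromatic carbon of the phenyl on the shared core and says nothing about the aryl on the amine nitrogen in a ring.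

Compound 4 `Cc1cc(C)cc(N2CCN(C(=O)c3oc(C)nc3-c3ccccc3)CC2)c1` differs from compound 1 by 3,5-dimethylphenyl in place of 2,5-dimethylphenyl on an amine nitrogen in a ring. Going by the values given here, no measured step touches this position, so the expectation rests on compound 1 alone with broad uncertainty. Since the change keeps the same atoms and only moves a methyl on the 3,5-dimethylphenyl, the estimate for compound 4 is 80 nM, with a range from 20 nM to 400 nM. The step this implies, a 2.6-fold higher number from compound 1 to compound 4 (0.41 log units; beyond the scatter), is an expected mild loss that may well sit within the scatter.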

Compound 4, half-maximal inhibitory concentration: 34.5 nM
For compound 4 the middle estimate is 2.3-fold (0.37 log units) above the measured one, and the stated range covers the measured number.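

In this assay, among the compounds shown here, 3,5-dimethylphenyl in place of 2,5-dimethylphenyl on the amine nitrogen in a ring gives a 1.1-fold higher number from compound 1 to compound 4 (0.04 log units; within the scatter), the first measured step at this position. For the compounds shown here, the two dimethylphenyl groups therefore cannot be told apart in this read-out, and the placement of this methyl on the aryl carries no measurable weight for this pair, in contrast to the only other measured step, an at least 31-fold higher number from compound 1 to compound 2 (1.50 log units; beyond the scatter), which concerns chloro on the phenyl of the shared core. The information available gives no reason for this outcome at the aryl on the amine nitrogen.

Only these two dimethylphenyl groups are shown at this position, so it remains open whether an unsubstituted phenyl, or a methoxy group, a chloro group or a carboxylic acid on that aryl, would keep the number in the same range. Going by these compounds, it also remains open whether chloro on the phenyl of the shared core would have the same consequence when the group on the amine nitrogen is 3,5-dimethylphenyl.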